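A longer chain on compound 1: an expected outcome

A few compounds are considered here, and "the series" means these few. Any claim that something is new, unique, unknown or untested is made for them only; others in the source may bear on it.

Compound 1 `CCCCCCCO/N=C/c1cc(OC)c2c(c1OC)C(=O)C=CC2=O` was tested in a functional assay on A549 cells (Homo sapiens) for antiproliferative activity; on this read-out lower numbers stand for an effect already at smaller amounts and higher numbers for an effect only at larger amounts of compound. In this assay compound 1 reaches only > 10 ug/mL, which is a limit of the assay and not a number. Compound 2 `CCCCCC/C(=N\OC)c1cc(OC)c2c(c1OC)C(=O)C=CC2=O` has also been measured. In this assay compound 2 likewise stops at > 10 ug/mL, again a limit rather than a number. Among the compounds with values here, both values therefore sit at the limit of > 10 ug/mL in this assay, at which 2 of the 2 values shown sit, so no numbered value is at hand for either compound, and no step between them can be sized.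

Compound 3 `CCCCCCCCCO/N=C/c1cc(OC)c2c(c1OC)C(=O)C=CC2=O` has not yet been measured. It differs from compound 1 by ethyl in place of hydrogen on a saturated chain carbon, seven bonds along the chain from an oxygen on an unsaturated carbon. With every measured compound resting at the limit of > 10 ug/mL in this assay, at which 2 of the 2 values shown sit, compound 3 is expected to stay there as well, the step that the limit leaves unreadable from compound 1 to compound 3 amounting to nothing beyond the scatter. The estimate for compound 3 is 15 ug/mL, with a range from 5 ug/mL to 50 ug/mL.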

Compound 3, concentration for half-maximal effect: > 10 ug/mL
Compound 3 was reported as a limit (the forecaster's own chance of this, stated with the estimate: 80%); the middle value does not contradict the limit.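

Compound 1 and compound 3 both end at a limit in this assay, so no step can be read between them: the limit of > 10 ug/mL in this assay, at which 3 of the 3 values shown sit.

The compounds shown leave open how strong each one really is, and whether any chain on the shared core would give a numbered value in this assay.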